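Swapping the amide acyl group on a trimethoxyphenyl amide

This account rests on a few compounds, and the source may have more. Where it says the series, first, only, none or still open, it means among the compounds named here.

Measured so far:
compound 1, `C/C=C/C(=O)N(Cc1ccc(OC)c([N+](=O)[O-])c1)c1cc(OC)c(OC)c(OC)c1`, gives 510 nM in a functional assay on KYSE-450 cells (Homo sapiens) for inhibition, read by MTT assay, with a stated time of 48 h; on this read-out lower numbers stand for stronger inhibition and higher numbers for weaker inhibition
compound 2, `COCC(=O)N(Cc1ccc(OC)c(O)c1)c1cc(OC)c(OC)c(OC)c1`, gives 460 nM in this assay

Among the compounds with values here, only two compounds have been measured, and in this assay compound 2 stands alongside compound 1: the two numbers lie within the usual scatter of each other, so neither can be called the more potent. Both share the same core, a trimethoxyphenyl amide carrying a benzyl group, and differ from each other in two places at once. Within the data shown here, no single step between them can be drawn.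

Compound 3, `COc1ccc(CN(C(=O)C=C(C)C)c2cc(OC)c(OC)c(OC)c2)cc1O`, keeps the hydroxyl-bearing benzyl side of compound 2 and changes only the acyl side: 2-methylprop-1-en-1-yl in place of methoxymethyl on a carbonyl carbon. Among the measured compounds shown here, the acyl group is the only part that moves, and the one comparison available, compound 1 against compound 2, shows that a different acyl group together with a different ring substituent leaves the number about where it was.

On that basis the step of a 1.1-fold lower number from compound 2 to compound 3 (0.04 log units; within the scatter) is expected to stay within the scatter, with no clear direction. Compound 3 is therefore estimated at 420 nM in this assay, with a likely range from 150 nM to 1200 nM.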

Compound 3, half-maximal inhibitory concentration: 280 nM
The estimate for compound 3 lay 1.5-fold (0.18 log units) above the measured number; the measured number falls inside the stated range.
By their numbers in this assay, from the lowest: compounds 3, 2 and 1 (each within the scatter of the next).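

In this assay, within the data shown here, replacing methoxymethyl with 2-methylprop-1-en-1-yl on the carbonyl carbon gives a 1.6-fold lower number from compound 2 to compound 3 (0.22 log units; within the scatter), the first comparison here in which only one part of the molecule differs. For this one pair, the acyl side can lose the oxygen of methoxymethyl and gain a double bond outside the aromatic rings, yet the two compounds cannot be told apart on this read-out, so this particular swap gives no sign that the oxygen or the double bond matters for the number. Nothing available bears on why the two numbers lie so close together.

Going by these compounds, a single pair cannot show how much this position tolerates in general, and it remains unknown whether an aminomethyl group, a carboxylic acid or a longer alkyl chain on the same carbonyl carbon would move the number beyond the scatter. Among these compounds, the benzyl side also remains unresolved, since no pair here isolates a change from the hydroxyl to the nitro group with the acyl group held fixed.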